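Methoxy in place of fluoro: an expected cytotoxicity read-out

The source may report more compounds than this note shows. Statements on the series, on what has been measured and on what is new or still open speak of the compounds shown alone.

Measured compounds:
Compound 1 `O=C(N/N=C/c1ccc(Cl)cc1)c1cnccn1` gives 64% in an ADME assay on J774 cells (Mus musculus) for cytotoxicity, read by MTT assay, with a stated time of 48 h, tested at 100 ug/mL; on this read-out lower numbers stand for a stronger effect and higher numbers for a weaker effect at the one concentration tested.
Compound 2 `O=C(N/N=C/c1ccc(F)cc1)c1cnccn1` gives 69% in this assay.

Among the two numbers available, compound 2 holds the higher one, but its only neighbour is compound 1, and the single measured step, a number 5 percentage points higher from compound 1 to compound 2 (within the scatter), lies within the scatter, so the two compounds cannot be told apart on this read-out. That step exchanges one halogen for another on the aromatic carbon.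

Compound 3 `COc1ccc(/C=N/NC(=O)c2cnccn2)cc1` is not yet measured in this assay. It differs from compound 2 by methoxy in place of fluoro on an aromatic carbon.

Going by the values given here, no measured step brings a methoxy group in or takes one out, so the only guidance is the halogen step a number 5 percentage points higher from compound 1 to compound 2 (within the scatter), which was small. On that basis the step from compound 2 to compound 3 is expected to stay within the scatter, a number 2 percentage points lower from compound 2 to compound 3 (within the scatter), with wide uncertainty. Compound 3 is therefore estimated at 67% in this assay, with a range from 50% to 85%.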

Compound 3, a percentage reported as activity, at one concentration (the size of the read-out at that concentration, not a potency): 55%
Estimate against measurement, compound 3: 12 percentage points above; measured number inside the range.
By their numbers in this assay, from the lowest: compounds 3, 1 and 2 (each within the scatter of the next, the first and the last beyond it).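

Methoxy on this aromatic carbon, para to a large group, gives the first step at this position in this assay that passes the scatter, with a number 14 percentage points lower from compound 2 to compound 3 (beyond the scatter) as a modest change. The same group set against chloro gives a number 9 percentage points lower from compound 1 to compound 3 (within the scatter), so methoxy separates from fluoro but not from chloro, and the position proves able to respond to a change that is not an exchange of one halogen for another. No available evidence accounts for this difference.

The compounds shown leave open whether an amine or a carboxylic acid on the same aromatic carbon would give a step beyond the scatter, and in which direction. They also leave open whether ethoxy or a longer alkoxy chain would follow methoxy or behave differently.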